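The source may report more compounds than this note shows. Statements on the series, on what has been measured and on what is new or still open speak of the compounds shown alone.

For the measured compounds named here, in a functional assay on CAKI-1 cells (Homo sapiens) for antiproliferative activity, read by sulforhodamine B assay, with a stated time of 48 h (on this read-out lower numbers stand for stronger inhibition and higher numbers for weaker inhibition), compound 1 `O=C(NCCCNc1cc(-c2cn(-c3ccccc3)nc2-c2cccc(O)c2)ccn1)Nc1ccc(F)cc1` gives 2040 nM and compound 2 `O=C(NCCCNc1cc(-c2cn(-c3ccccc3)nc2-c2cccc(O)c2)ccn1)Nc1cccc(C(F)(F)F)c1` gives 1900 nM, so compound 1 sits within the scatter of the only other number. Compound 3 `COc1cccc(-c2nn(-c3ccccc3)cc2-c2ccnc(NCCCNC(=O)Nc3ccc(F)cc3)c2)c1` carries methyl in place of hydrogen on an oxygen on an aromatic ring, which reads as 3-hydroxyphenyl to 3-methoxyphenyl. Going by the values given here, the one measured step, a 1.1-fold lower number from compound 1 to compound 2 (0.03 log units; within the scatter), concerns the aryl on an amide-type nitrogen, and no measured step touches this oxygen. No shift beyond the scatter is therefore expected in this assay. The expected step is a 1.2-fold higher number from compound 1 to compound 3 (0.09 log units; within the scatter). For compound 3 the estimated value is 2500 nM, with an expected range from 900 nM to 7000 nM.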

Compound 3, half-maximal inhibitory concentration: 8630 nM
Compound 3: middle estimate off by 3.5-fold (0.54 log units), on the low side, outside the stated range (above it).
By their numbers in this assay, from the lowest: compounds 2 and 1 (each within the scatter of the next); then compound 3.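

Methyl in place of hydrogen on this oxygen gives a 4.2-fold higher number from compound 1 to compound 3 (0.63 log units; beyond the scatter) in this assay and is the first change in the series to move beyond the scatter, unlike a 1.1-fold lower number from compound 1 to compound 2 (0.03 log units; within the scatter) on the aryl of the amide-type nitrogen. The 3-hydroxyphenyl position is therefore sensitive to a single added methyl, and hydroxy gives the lower number of the two groups compared here. No available evidence bears on the reason for this shift.

From the compounds shown here alone, whether an amino group or an ethoxy group at this place would stay nearer to compound 1 remains open. Also open, going by these compounds, is whether the same methyl produces a similar shift on compound 2.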